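Swapping phenyl for oxan-4-yl on the sulfonyl

The source may hold more compounds than are shown below. What is called first, only, known or untested is meant among the compounds shown, and "the series" means these compounds.

- compound 1 `O=C(NCc1ccc(S(=O)(=O)c2ccccc2)cc1)N1Cc2ccncc2C1`: 115000 nM
- compound 2 `O=S(=O)(c1ccccc1)c1ccc(CNS(=O)(=O)N2Cc3ccncc3C2)cc1`: 3000 nM

In a physicochemical assay for solubility, in phosphate buffer, with a stated time of 24 h, at pH 7.4, tested at 100 uM (a higher number here means a more soluble compound, a lower number a less soluble compound), compound 1 gives 115000 nM, the higher of the two numbers, while compound 2 gives 3000 nM, a gap beyond the usual scatter. Compound 3 `O=C(NCc1ccc(S(=O)(=O)C2CCOCC2)cc1)N1Cc2ccncc2C1` keeps the core of compound 1 but carries oxan-4-yl in place of phenyl on a sulfonyl sulfur. Among the measured compounds shown here, no measured pair shows this change, so any forecast is tentative. The expected step of a 1.0-fold higher number from compound 1 to compound 3 (0.02 log units; within the scatter) stays within the scatter because compound 1 at 115000 nM already lies near the concentration tested. The estimate for compound 3 is 120000 nM, with an expected range of 65000 nM to 200000 nM.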

Compound 3, solubility: 206000 nM
Compound 3: middle estimate off by 1.7-fold (0.23 log units), on the low side; the measured number lies above the stated range.
By their numbers in this assay, from the lowest: compound 2; then compounds 1 and 3 (each within the scatter of the next).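

In this assay, putting oxan-4-yl in place of phenyl on a sulfonyl sulfur gives a 1.8-fold higher number from compound 1 to compound 3 (0.25 log units; within the scatter), so this first look at the position shows an aromatic ring and a non-aromatic ring holding one oxygen reading alike. Both numbers lie past the concentration tested, so a real difference could stay hidden. Nothing measured here offers an explanation for this result. Going by these compounds, it remains open whether an amine such as piperidin-4-yl, or a carboxylic acid, at this sulfonyl sulfur would read the same. On these data alone, the same swap on compound 2, which has more room to rise, also remains open.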